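Taking the chloro off compound 1

This account rests on a few compounds, and the source may have more. Where it says the series, first, only, none or still open, it means among the compounds named here.

In a functional assay on U-87MG ATCC cells for antiproliferative activity against U-87 MG (Homo sapiens), read by MTT assay, with a stated time of 48 h (on this read-out lower numbers stand for stronger inhibition and higher numbers for weaker inhibition), compound 1 `COc1ccc(-c2nc(C)c(C(=O)CSc3nc(-c4ccc(Cl)cc4)c(C#N)c(=O)[nH]3)s2)cc1` gives 45900 nM. Compound 2 `Cc1nc(-c2ccccc2)sc1C(=O)CSc1nc(-c2ccc(Cl)cc2)c(C#N)c(=O)[nH]1` gives 43400 nM, and compound 3 `Cc1nc(-c2ccc(Cl)cc2)sc1C(=O)CSc1nc(-c2ccc(Cl)cc2)c(C#N)c(=O)[nH]1` gives 53000 nM. These three values lie within the scatter of one another, so compound 1 has no separate place among them.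

Compound 4 `COc1ccc(-c2nc(C)c(C(=O)CSc3nc(-c4ccccc4)c(C#N)c(=O)[nH]3)s2)cc1` has not yet been measured. It departs from compound 1 by hydrogen in place of chloro on an aromatic carbon, which is hydrogen in place of chloro on an aromatic carbon, or 4-chlorophenyl to phenyl.

Going by the values given here, no measured pair changes this 4-chlorophenyl group. All three measured steps act on a different aromatic ring, the one that carries the methoxy in compound 1. They are a 1.1-fold lower number from compound 1 to compound 2 (0.02 log units; within the scatter), a 1.2-fold higher number from compound 1 to compound 3 (0.06 log units; within the scatter) and a 1.2-fold higher number from compound 2 to compound 3 (0.09 log units; within the scatter). The last is the closest in kind, since it exchanges hydrogen and chloro, but it does so at that other ring. Every one of these steps stays within the scatter, so the evidence is indirect and gives no direction for the new change.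

In this assay, no shift beyond the scatter is expected, and the estimated step is a 1.0-fold higher number from compound 1 to compound 4 (0.02 log units; within the scatter). For compound 4 the expected value is 48000 nM, with an estimated range from 24000 nM to 96000 nM.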

Compound 4, half-maximal inhibitory concentration: 57300 nM
Compound 4: the middle estimate sits 1.2-fold (0.08 log units) below what was measured; the measured number falls inside the stated range.
By their numbers in this assay, from the lowest: compounds 2, 1, 3 and 4 (each within the scatter of the next).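

Going by these compounds alone, the first reading at this position in this assay is a 1.2-fold higher number from compound 1 to compound 4 (0.10 log units; within the scatter), so 4-chlorophenyl to phenyl, on a carbon para to a large group, stays within the scatter. On the core of compound 1, the chloro at this position therefore has no readable effect on the number. Hydrogen in place of chloro has now been read on both aromatic rings, and neither step leaves the scatter, nor do the two steps separate from each other: the same change on two cores in this assay, a 1.2-fold higher number (0.09 log units; within the scatter) from compound 2 to compound 3 and a 1.2-fold lower number (0.10 log units; within the scatter) from compound 4 to compound 1, 1.5-fold (0.18 log units) apart, within the scatter of two such steps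

The compounds shown leave open whether any group at this position can move the number away from the level of compound 1 at 45900 nM, since only hydrogen and chloro have been compared here; an amine or a carboxylic acid on this phenyl ring would test that with a change of a different kind. They also leave open whether the same absence of effect would hold in a combination of changes on both aromatic rings, or whether a longer chain in place of the chloro would behave as hydrogen does.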